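This account rests on a few compounds, and the source may have more. Where it says the series, first, only, none or still open, it means among the compounds named here.

In a physicochemical assay for solubility, in phosphate buffer, at pH 6.8 (a lower number here means a less soluble compound, a higher number a more soluble compound), compound 3 (`CCn1c(N[C@H]2CC[C@H](C(=O)O)CC2)nc2ccsc2c1=O`) gives 450 ug/mL on a level with compound 1 (`CCn1c(NC2CC2)nc2ccsc2c1=O`) at 430 ug/mL and far over compound 2 (`CCn1c(N[C@H]2CC[C@H](C(=O)OC)CC2)nc2ccsc2c1=O`) at 13 ug/mL in the same test. Compound 4 (`CCn1c(N[C@H]2CC[C@H](O)CC2)nc2ccsc2c1=O`) carries hydroxy in place of carboxy on a saturated ring carbon and differs from compound 3 in nothing else. Within the data shown here, the one measured step at that ring carbon is the large 35-fold higher number from compound 2 to compound 3 (1.54 log units; beyond the scatter) and it swaps methyl for hydrogen without involving hydroxy, so it offers only a loose guide. A moderate fall is expected, with the estimated step being a 3.0-fold lower number from compound 3 to compound 4 (0.48 log units; beyond the scatter) and thus smaller than that measured one. Compound 4 is expected at 150 ug/mL with a range from 40 ug/mL to 500 ug/mL as estimated.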

Compound 4, solubility: 74 ug/mL
Beside the measured number, compound 4's estimate is 2.0-fold (0.31 log units) above it; the measured number falls inside the stated range.
By their numbers in this assay, from the lowest: compound 2; then compound 4; then compounds 1 and 3 (each within the scatter of the next).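

In this assay the saturated ring carbon now has a third group, and hydroxy in place of carboxy gives a 6.1-fold lower number from compound 3 to compound 4 (0.78 log units; beyond the scatter) at that carbon. Hydroxy in place of methoxycarbonyl gives a 5.7-fold higher number from compound 2 to compound 4 (0.76 log units; beyond the scatter) in the opposite direction. Carboxy and hydroxy share the same computed donor and acceptor counts and no net charge, so those counts do not separate compound 3 from compound 4. No measurement here bears on the reason for these steps. From the compounds shown here alone, how an amine or an amide on this carbon would compare remains open.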